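The source may report more compounds than this note shows. Statements on the series, on what has been measured and on what is new or still open speak of the compounds shown alone.

Of the compounds shown here, three have so far been tested in an ADME assay on NCM460 cells (Homo sapiens) for cytotoxicity, read by MTT assay, with a stated time of 72 h; on this read-out higher numbers stand for weaker inhibition and lower numbers for stronger inhibition. Compound 1 `CCc1cccc(NC(=O)c2cccc(/C=C3\CC(=O)N(Cc4ccccc4)C3=O)c2)c1` gives > 100000 nM, which is a limit of the assay rather than a number. Compound 2 `Cc1ccc(NC(=O)c2cccc(/C=C3\CC(=O)N(c4ccccc4)C3=O)c2)cc1C` likewise gives > 100000 nM, again a limit of the assay. Compound 3 `Cc1ccc(N2C(=O)C/C(=C\c3cccc(C(=O)Nc4ccc(Cl)cc4)c3)C2=O)cc1` gives > 100000 nM, once more a limit. Among the measured compounds shown here, compound 2 therefore stands exactly where every measured member stands, at the limit of > 100000 nM in this assay, at which 3 of the 3 values shown sit, and no measured compound can be set apart from another. For the measured compounds named here, no step between measured compounds can be drawn, since each measured value is a limit.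

Compound 4 `O=C(c1cccc(/C=C2\CC(=O)N(c3ccccc3)C2=O)c1)N1CCCC1` has not yet been tested in this assay. It differs from compound 2 in one place: pyrrolidin-1-yl in place of (3,4-dimethylphenyl)amino on a carbonyl carbon. Because all three measured values sit at the limit of > 100000 nM in this assay, at which 3 of the 3 values shown sit, the measured compounds give no way to tell one amide substituent from another in this assay, and they offer no ground for expecting a step in either direction beyond the scatter. The expected step from compound 2 to compound 4 is accordingly none beyond the scatter, a step that the limit leaves unreadable from compound 2 to compound 4. On that footing compound 4 is estimated at 150000 nM, with a range from 50000 nM to 450000 nM, and most likely it will again be reported only as a limit.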

Compound 4, half-maximal inhibitory concentration: > 100000 nM
Compound 4 ended at the assay's limit; the forecaster's own chance of this, stated with the estimate: 85%; the middle value lies beyond the limit too.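

Compound 2 and compound 4 both end at a limit of the assay, so no step can be read between them, and the exchange of (3,4-dimethylphenyl)amino for pyrrolidin-1-yl has no readable size: the limit of > 100000 nM in this assay, at which 4 of the 4 values shown sit. The compounds shown leave open whether any amide substituent on the shared core gives a value inside the assay's measurable range.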